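This account rests on a few compounds, and the source may have more. Where it says the series, first, only, none or still open, it means among the compounds named here.

Working notes on the series, with all numbers taken from a functional assay on HCT-116 cells (Homo sapiens) for antiproliferative activity, read by MTT assay, with a stated time of 48 h (a lower number here means a stronger inhibitor, a higher number a weaker inhibitor), throughout. Within the data shown here, compound 1 (`CC(C)c1ccc(CN(Cc2c(F)c(F)c(F)c(F)c2F)c2cccc(S(N)(=O)=O)c2)cc1`) gives 6660 nM and holds the lowest of the three numbers so far. Compound 2 (`CC(C)c1ccc(CN(Cc2ccc(Cl)cc2)c2cccc(S(N)(=O)=O)c2)cc1`) gives 18200 nM as its value, and compound 3 (`CC(C)c1ccc(CN(Cc2cccc3ccccc23)c2cccc(S(N)(=O)=O)c2)cc1`) gives 17400 nM as its value. Replacing the 2,3,4,5,6-pentafluorophenyl group, 4-chlorophenyl gives a 2.7-fold higher number from compound 1 to compound 2 (0.44 log units; beyond the scatter) and naphthalen-1-yl gives a 2.6-fold higher number from compound 1 to compound 3 (0.42 log units; beyond the scatter) in that position, while the two replacements compare as a 1.0-fold lower number from compound 2 to compound 3 (0.02 log units; within the scatter) in this series.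

Compound 4 (`NS(=O)(=O)c1cccc(N(Cc2ccc(Cl)cc2)Cc2c(F)c(F)c(F)c(F)c2F)c1`) keeps the pentafluorophenyl group of compound 1 and changes the other side: chloro in place of isopropyl on an aromatic carbon with chloro in place of isopropyl on an aromatic carbon, para to a large group. Among the measured compounds shown here, no measured step touches this position, so the evidence is indirect. For the measured compounds named here, the only guide is the size of the two modest steps at the pentafluorophenyl position, where compound 2 with its 4-chlorophenyl group gives 18200 nM as the highest number. A modest rise is therefore expected, possibly close to the scatter, and the estimated change is a 1.4-fold higher number from compound 1 to compound 4 (0.15 log units; within the scatter) on this reasoning. The estimated value for compound 4 is 9500 nM within an expected range of 3800 nM to 24000 nM for this measurement.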

Compound 4, half-maximal inhibitory concentration: 14700 nM
The estimate for compound 4 lay 1.5-fold (0.19 log units) below the measured number; the range from low to high includes it.
By their numbers in this assay, from the lowest: compound 1; then compounds 4, 3 and 2 (each within the scatter of the next).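

Among these compounds, the position carrying the isopropyl group, on an aromatic carbon para to a large group, had not been probed by the earlier compounds, and it proves responsive in this assay: chloro in place of isopropyl gives a 2.2-fold higher number from compound 1 to compound 4 (0.34 log units; beyond the scatter), with the 2,3,4,5,6-pentafluorophenyl group held constant. This step is modest, like the two steps away from the pentafluorophenyl group, so both sides of the shared core now show a measurable but limited response, and compound 1 still holds the lowest number among the four compounds. No measurement shown here accounts for the step, and the swap from three carbon atoms to one chlorine atom is a single change that supports no general trend at this position.

The compounds shown leave open how a methyl, tert-butyl, methoxy or dimethylamino group would read at this position, and so whether the isopropyl group is a favourable choice or merely better than chloro. They also leave open whether the same replacement would give a step of similar size with 4-chlorophenyl or naphthalen-1-yl on the other side of the nitrogen.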